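The source may report more compounds than this note shows. Statements on the series, on what has been measured and on what is new or still open speak of the compounds shown alone.

Compound 1 `Nc1cc(-c2cccc(-n3ccc4cc(C5CC5)cc(F)c4c3=O)c2CO)nc(Nc2cnn(C3CC3)c2)n1` was tested in an ADME assay on Caco-2 cells (Homo sapiens) for permeability (on this read-out lower numbers stand for lower permeability and higher numbers for higher permeability), where compound 1 gives 6.9 10^-6 cm/s. Among the measured compounds shown here, its only measured companion is compound 2 `CC(C)(C)n1cc(Nc2nc(N)cc(-c3cccc(-n4ccc5cc(C6CC6)cc(F)c5c4=O)c3CO)n2)cn1`, which in this assay gives 5.7 10^-6 cm/s. The two numbers sit close together, so compound 1 cannot be told apart from compound 2 on this read-out. For the measured compounds named here, the one step between them, a 1.2-fold lower number from compound 1 to compound 2 (0.08 log units; within the scatter), puts tert-butyl in place of cyclopropyl on an aromatic nitrogen and leaves the permeability number essentially where it was.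

Compound 3 `Cn1cc(Nc2nc(N)cc(-c3cccc(-n4ccc5cc(C6CC6)cc(F)c5c4=O)c3CO)n2)cn1` has not yet been measured. It differs from compound 1 by methyl in place of cyclopropyl on an aromatic nitrogen. Going by the values given here, the tert-butyl step is the only measured comparison that bears on this change, since it alters the same cyclopropyl on the same aromatic nitrogen, and that step stayed within the scatter. Nothing in the data points in either direction for the methyl, so the expected step, a 1.1-fold lower number from compound 1 to compound 3 (0.03 log units; within the scatter), is one within the scatter. Compound 3 is therefore estimated at 6.5 10^-6 cm/s in this assay, with a range from 3.5 10^-6 cm/s to 12 10^-6 cm/s.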

Compound 3, apparent permeability in the Caco-2 assay: 6.3 10^-6 cm/s
The estimate for compound 3 lay 1.0-fold (0.01 log units) above the measured number, within the range that was stated.
By their numbers in the Caco-2 assay, from the lowest: compounds 2, 3 and 1 (each within the scatter of the next).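

Among the compounds shown here, the opening comparison held only one swap on this aromatic nitrogen; in the Caco-2 assay, two further steps (a 1.1-fold lower number from compound 1 to compound 3 (0.04 log units; within the scatter) and a 1.1-fold higher number from compound 2 to compound 3 (0.04 log units; within the scatter)) now show that methyl, with 1 heavy atom and no ring in place of the 3 heavy atoms and three-membered ring of cyclopropyl, also leaves the number within the scatter. In the Caco-2 assay compound 1 gives 6.9 10^-6 cm/s while compound 2 gives 5.7 10^-6 cm/s and compound 3 gives 6.3 10^-6 cm/s, so compound 1, compound 2 and compound 3 cannot be told apart on this read-out. The comparison also reaches a second kind of measurement: in a physicochemical assay for solubility, read by LC-MS, in phosphate buffer, measured as kinetic solubility, with a stated time of 1 h, at pH 7.4 (on this read-out lower numbers stand for lower solubility and higher numbers for higher solubility), compound 1 gives 9800 nM and compound 3 gives 18000 nM, and the same change gives a step (a 1.8-fold higher number from compound 1 to compound 3 (0.26 log units; within the scatter)) that likewise cannot be separated from repeat-to-repeat variation, so neither read-out distinguishes methyl from cyclopropyl at this position. No supporting measurement is available to explain why these numbers stay together.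

All three groups shown here are built from carbon alone, so it remains open whether an amine, a carboxylic acid or a longer chain ending in a hydroxyl group on this nitrogen would also leave the numbers within the scatter. In the physicochemical assay, the reading rests on a single step, so it cannot yet show how groups other than methyl and cyclopropyl behave at this position.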